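Cytotoxicity series: replacing the dihydroxyphenyl group with imidazolyl

This account rests on a few compounds, and the source may have more. Where it says the series, first, only, none or still open, it means among the compounds named here.

Measured so far:
compound 1, `Cc1cc(-c2c(F)cc3c(=O)c(Cc4c(O)cc(O)cc4O)cn(C4CC4)c3c2F)cc(C)n1`: 470 nM
compound 2, `Cc1cc(-c2c(F)cc3c(=O)c(Cc4c(O)cccc4O)cn(C4CC4)c3c2F)cc(C)n1`: 250 nM

Both numbers come from a functional assay on P388 cells (Mus musculus) for cytotoxicity; a lower number here means a stronger inhibitor, a higher number a weaker inhibitor. Among the measured compounds shown here, compound 2 gives the lowest of the two numbers in this assay, but its only neighbour is compound 1, and the single measured step, a 1.9-fold lower number from compound 1 to compound 2 (0.27 log units; within the scatter), lies within the scatter, so no order between them can be claimed.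

Compound 3, `Cc1cc(-c2c(F)cc3c(=O)c(Cc4ncc[nH]4)cn(C4CC4)c3c2F)cc(C)n1`, has not yet been measured. Its change from compound 2 is 1H-imidazol-2-yl in place of 2,6-dihydroxyphenyl on a saturated chain carbon bound to an aromatic carbon. For the measured compounds named here, no measured step touches this change; the one step available only trims a hydroxy and stays within the scatter. The expectation for compound 3 is therefore weak, with a wide range: the step of a 1.6-fold higher number from compound 2 to compound 3 (0.20 log units; within the scatter) is expected to stay near the scatter, in either direction. Compound 3 is estimated at 400 nM, between 100 nM and 2000 nM.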

Compound 3, half-maximal inhibitory concentration: 1100 nM
Estimate against measurement, compound 3: 2.8-fold (0.44 log units) below, within the range that was stated.
By their numbers in this assay, from the lowest: compounds 2 and 1 (each within the scatter of the next); then compound 3.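

In this assay, 1H-imidazol-2-yl in place of 2,6-dihydroxyphenyl on a saturated chain carbon bound to an aromatic carbon gives a 4.4-fold higher number from compound 2 to compound 3 (0.64 log units; beyond the scatter) and so, unlike the hydroxy trim, moves the number beyond the scatter. Replacing 2,4,6-trihydroxyphenyl at the same place gives a 2.3-fold higher number from compound 1 to compound 3 (0.37 log units; beyond the scatter) and points the same way, so this position responds to the group it carries, though modestly. Nothing given here accounts for the shift. Still open, as far as these compounds go, is whether the shift follows the hydroxy groups or the ring itself; an unsubstituted phenyl or a pyridyl group at this place would separate the two.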